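Replacing 2-hydroxyethyl in compound 1

The compounds below may be only part of what the source reports. "The series", "measured", "known", "first", "only" and "open" are said of these compounds alone.

In a functional assay on NCI-H460 cells (Homo sapiens) (on this read-out higher numbers stand for weaker inhibition and lower numbers for stronger inhibition), compound 1 `COc1cc(NC(C)CCCNC(=O)NCCO)c2ncccc2c1` gives > 100000 nM. From the compounds shown here alone, this is a limit of the assay and not a number, so the true position of compound 1 is unknown. Compound 3 `COc1cc(NC(C)CCCNC(=O)NC(CO)(CO)CO)c2ncccc2c1` keeps the shared core and places 2-hydroxy-1,1-bis(hydroxymethyl)ethyl in place of 2-hydroxyethyl on an amide-type nitrogen.

Going by the values given here, only one measured step offers guidance. In this assay, compound 2 `COc1cc(NC(C)CCCNC(=O)NCCCCCO)c2ncccc2c1` gives 2000 nM, a measured number. The step is large: an at least 50-fold lower number from compound 1 to compound 2 (1.69 log units; beyond the scatter). Among the compounds with values here, it puts 3-hydroxypropyl in place of hydroxy on the same side chain, which is a different change from the one in compound 3. The gain seen with compound 2 at 2000 nM is therefore not expected to carry over, and no clear move toward lower numbers is anticipated. The expected outcome is a result close to the limit, possibly again reported only as a limit. The estimated change is an at least 1.2-fold lower number from compound 1 to compound 3 (0.09 log units; that floor lies within the scatter). Compound 3 is expected at 80000 nM, with an estimated range of 20000 nM to 150000 nM.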

Compound 3, half-maximal inhibitory concentration: > 100000 nM
Compound 3: no number, only a limit (the forecaster's own chance of this, stated with the estimate: 65%); middle value at least 1.2-fold (0.09 log units) from the limit.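

In this assay compound 3 gives > 100000 nM, which is a limit of the assay and not a number. The step between compound 1 and compound 3 cannot be read, because both compounds sit at that limit: the limit of > 100000 nM in this assay, at which 2 of the 3 values shown sit.

On the amide-type nitrogen, the change from 5-hydroxypentyl to 2-hydroxy-1,1-bis(hydroxymethyl)ethyl gives an at least 50-fold higher number from compound 2 to compound 3 (1.69 log units; beyond the scatter), so a larger group here does not by itself bring a measurable value: 2-hydroxy-1,1-bis(hydroxymethyl)ethyl has 7 heavy atoms against 3 in 2-hydroxyethyl, yet compound 3 still yields only a limit.

The compounds shown leave open how far compound 1 and compound 3 truly lie from each other, since neither has a number. They also leave open whether the measured value of compound 2 depends on the length of its chain or on its hydroxy group, a question that a plain pentyl group or a 5-aminopentyl group on the same nitrogen would help to answer.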